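The compounds below may be only part of what the source reports. "The series", "measured", "known", "first", "only" and "open" are said of these compounds alone.

Among the compounds with values here, in a functional assay on cells (CNS carcinoma cell, Homo sapiens) for cytotoxicity, read by sulforhodamine B assay, with a stated time of 48 h (on this read-out higher numbers stand for weaker inhibition of growth and lower numbers for stronger inhibition of growth), compound 1 (`COc1ccc2c(c1)/C(=C\c1c(OC)nc3sc(C)cn13)C(=O)N2`) reads 430 nM and compound 2 (`COc1nc2sc(C)cn2c1/C=C1/C(=O)Nc2ccc(O)cc21`) reads 4760 nM as the higher of the only two numbers, so compound 2 shows the weaker inhibition of growth. The next compound to consider is compound 3 (`COc1nc2sc(C)cn2c1/C=C1/C(=O)Nc2ccccc21`), which differs from compound 2 as follows: hydrogen in place of hydroxy on an aromatic carbon. Within the data shown here, one measured step bears on this change. The number rose with an 11-fold higher number from compound 1 to compound 2 (1.04 log units; beyond the scatter) when hydrogen took the place of methyl on an oxygen on an aromatic ring, a large step beyond the scatter. Among the measured compounds shown here, compound 3 lacks that oxygen altogether, and no measured compound has hydrogen on that carbon, so the data only loosely fix the size of the next step. For the measured compounds named here, with compound 2 at 4760 nM as the only compound bearing hydroxy, a drop back toward the lower number is expected. The expected change is a 5.3-fold lower number from compound 2 to compound 3 (0.72 log units; beyond the scatter) in this assay and would lie beyond the scatter. For compound 3 the estimate is 900 nM with an expected range from 300 nM to 3000 nM in this assay for now.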

Compound 3, concentration for 50% growth inhibition: 1970 nM
Estimate against measurement, compound 3: 2.2-fold (0.34 log units) below, and the stated range covers the measured number.
By their numbers in this assay, from the lowest: compound 1; then compound 3; then compound 2.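

In this assay the change at this aromatic carbon does not run in one direction: replacing hydroxy with hydrogen gives a 2.4-fold lower number from compound 2 to compound 3 (0.38 log units; beyond the scatter) while replacing methoxy with hydrogen gives a 4.6-fold higher number from compound 1 to compound 3 (0.66 log units; beyond the scatter) and the compound with hydrogen therefore falls between the two compounds bearing oxygen. The earlier pair gave only the gap between methoxy and hydroxy, whereas hydrogen now serves as a reference point, with methoxy on the lower side and hydroxy on the higher side, both steps beyond the scatter, so the earlier gap cannot be assigned to one of these groups alone. Nothing available here explains this order of the three groups.

The compounds shown leave open whether a longer alkoxy group such as ethoxy, or an amine or a fluorine atom, on this carbon would read below methoxy or above hydroxy. They also leave open whether the same order of methoxy, hydrogen and hydroxy would hold with a different group elsewhere on the shared core.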